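The source may hold more compounds than are shown below. What is called first, only, known or untested is meant among the compounds shown, and "the series" means these compounds.

Compound 2 `CC1=C(C(=O)SC(C)(C)C)C(c2ccc(C)cc2)C=C(c2ccccc2)N1` gives 56200 nM in an assay on SH-SY5Y cells for inhibition of Voltage-dependent L-type calcium channel subunit alpha-1D (Homo sapiens), read by calcium flux, with a stated time of 15 min (on this read-out lower numbers stand for stronger inhibition and higher numbers for weaker inhibition), the highest of the two numbers recorded so far; compound 1 `CCOC(=O)C1=C(C)NC(c2ccccc2)=CC1c1ccc(OC)cc1` gives 29800 nM in this assay, and the two values lie within the scatter of each other. Compound 3 `CCOC(=O)C1=C(C)NC(c2ccccc2)=CC1c1ccc(C)cc1` differs from compound 2 in one place: ethoxy in place of (tert-butyl)sulfanyl on a carbonyl carbon. Among the measured compounds shown here, no step of this kind has been measured here, so no direction beyond the scatter can be read from the data. Because compound 1, which shares the ethoxycarbonyl, gives 29800 nM in this assay, compound 3 is expected to show a 1.9-fold lower number from compound 2 to compound 3 (0.27 log units; within the scatter), a step within the scatter. Compound 3 is estimated at 30000 nM, with a range from 12000 nM to 75000 nM.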

Compound 3, half-maximal inhibitory concentration: 20600 nM
Beside the measured number, compound 3's estimate is 1.5-fold (0.16 log units) above it; measured number inside the range.
By their numbers in this assay, from the lowest: compounds 3, 1 and 2 (each within the scatter of the next, the first and the last beyond it).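

In this assay, ethoxy in place of (tert-butyl)sulfanyl on a carbonyl carbon gives a 2.7-fold lower number from compound 2 to compound 3 (0.44 log units; beyond the scatter) and so provides the first readable, though modest, change at this position. Methyl in place of methoxy on an aromatic carbon gives a 1.4-fold lower number from compound 1 to compound 3 (0.16 log units; within the scatter) and shows no direction at that second place. Nothing measured here accounts for either step. The compounds shown leave open how an amine or hydroxy in place of ethoxy on a carbonyl carbon would read. They also leave open whether a longer chain such as butoxy would keep the lower number.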